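From Pyrrole to Pyrrolidine at the Same Aromatic Carbon

This account rests on a few compounds, and the source may have more. Where it says the series, first, only, none or still open, it means among the compounds named here.

Among the compounds with values here, compound 2 `CN1CCN(CCCS(=O)(=O)c2ccc3nc(NC(=O)NC(=O)c4cc(-n5cccc5)ccc4Cl)sc3c2)CC1` holds the lowest number of the two compounds measured so far in an assay on HEK293 cells for displacement of a labelled ligand from growth hormone secretagogue receptor type 1 (Homo sapiens), with a stated time of 60 min; on this read-out higher numbers stand for weaker inhibition and lower numbers for stronger inhibition: in this assay compound 2 gives 0.15 nM. Within the data shown here, its only neighbour, compound 1 `Cc1cc(C)n(-c2ccc(Cl)c(C(=O)NC(=O)Nc3nc4ccc(S(=O)(=O)CCCN5CCN(C)CC5)cc4s3)c2)n1`, differs at a single aromatic carbon, and in this assay compound 1 gives 1.3 nM. The step of an 8.7-fold lower number from compound 1 to compound 2 (0.94 log units; beyond the scatter) shows that swapping the ring at that carbon moved the number well beyond the scatter. Compound 3 `CN1CCN(CCCS(=O)(=O)c2ccc3nc(NC(=O)NC(=O)c4cc(N5CCCC5)ccc4Cl)sc3c2)CC1` keeps the shared core and alters the same carbon once more: pyrrolidin-1-yl in place of 1H-pyrrol-1-yl on an aromatic carbon. Among the measured compounds shown here, no measured step tests a change of exactly this kind, so the earlier step is the only guide, and it shows that this position can move the number strongly. A step of a 3.3-fold higher number from compound 2 to compound 3 (0.52 log units; beyond the scatter) toward a somewhat higher number is expected, with wide uncertainty. Compound 3 is therefore estimated at 0.5 nM, within a range from 0.1 nM to 2.5 nM.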

Compound 3, half-maximal inhibitory concentration: 0.29 nM
Compound 3: the middle estimate sits 1.7-fold (0.24 log units) above what was measured; the measured number falls inside the stated range.
By their numbers in this assay, from the lowest: compounds 2 and 3 (each within the scatter of the next); then compound 1.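

At this aromatic carbon, in this assay, the step of a 1.9-fold higher number from compound 2 to compound 3 (0.29 log units; within the scatter) lies within the scatter, so an aromatic five-membered ring and a non-aromatic one cannot be told apart here. The step of a 4.5-fold lower number from compound 1 to compound 3 (0.65 log units; beyond the scatter) lies beyond the scatter, which places pyrrolidin-1-yl, like 1H-pyrrol-1-yl, clearly apart from 3,5-dimethyl-1H-pyrazol-1-yl, so a low number at this position does not depend on the ring being aromatic. No outside evidence bears on this result.

The compounds shown leave open whether the two methyl groups or the second ring nitrogen sets compound 1 apart, a question that the unsubstituted pyrazol-1-yl group could address. They also leave open how this carbon responds to a larger ring such as piperidin-1-yl or to an open-chain amine such as dimethylamino.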